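This account rests on a few compounds, and the source may have more. Where it says the series, first, only, none or still open, it means among the compounds named here.

Measured in an ADME assay on Vero cells (Homo sapiens) for cytotoxicity against Vero (Chlorocebus sabaeus), read by MTT assay; a higher number here means a weaker inhibitor, a lower number a stronger inhibitor:
compound 1 `CCCCCC[C@H](O)C/C=C\CCCCCCCc1cc(O)cc(O)c1` gives 76000 nM
compound 2 `CC/C=C\C/C=C\C/C=C\CCCCCCCc1cc(OC(C)=O)cc(OC(C)=O)c1` gives 138000 nM
compound 3 `CCCCC/C=C\C/C=C\CCCCCCCc1cc(OC(C)=O)cc(OC(C)=O)c1` gives 124000 nM

Compound 3 stands second highest of the three numbers; its nearest neighbour is compound 2 and its furthest is compound 1, both within the scatter. The next compound is compound 4 `CCCCCC[C@@H](C/C=C\CCCCCCCc1cc(OC(C)=O)cc(OC(C)=O)c1)OC(C)=O`. How it differs from compound 3: a group of 11 heavy atoms (9 carbon, 2 oxygen; no ring) in place of a group of 7 heavy atoms (7 carbon; no ring), on a saturated chain carbon bound to a double-bonded chain carbon. Among the compounds with values here, the one measured step that touches this part of the chain, a 1.1-fold lower number from compound 2 to compound 3 (0.05 log units; within the scatter), stayed within the scatter, and compound 1, which carries a hydroxyl on a saturated chain carbon bound to a double-bonded chain carbon, sits within the scatter of compound 2 and compound 3. No step beyond the scatter is therefore expected in this assay. For compound 4 the expected step is a 1.1-fold lower number from compound 3 to compound 4 (0.05 log units; within the scatter). Compound 4 is estimated at 110000 nM, range 50000 nM to 250000 nM.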

Compound 4, half-maximal inhibitory concentration: 75000 nM
Beside the measured number, compound 4's estimate is 1.5-fold (0.17 log units) above it; measured number inside the range.
By their numbers in this assay, from the lowest: compounds 4, 1, 3 and 2 (each within the scatter of the next).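

On a saturated chain carbon bound to a double-bonded chain carbon, the group of 11 heavy atoms, with 2 hydrogen-bond acceptors and 1 defined stereocentre, in place of hept-1-en-1-yl gives a 1.7-fold lower number from compound 3 to compound 4 (0.22 log units; within the scatter) in this assay and, against the other all-carbon chain, a 1.8-fold lower number from compound 2 to compound 4 (0.26 log units; within the scatter) as the second reading. This position therefore takes a chain bearing oxygen and a defined stereocentre with no step beyond the scatter, which the all-carbon change alone did not show. Nothing measured offers a cause for these numbers. Open, as far as these compounds go, is whether an amine or a carboxylic acid at this position would step beyond the scatter. Also open, from the compounds shown here alone, is whether a longer chain would do so.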